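Swapping a dimethyl oxazolyl group for a methyl pyrazolyl group

The source may report more compounds than this note shows. Statements on the series, on what has been measured and on what is new or still open speak of the compounds shown alone.

In a functional assay on KARPAS-422 cells (Homo sapiens) for inhibition, with a stated time of 72 h (on this read-out higher numbers stand for weaker inhibition and lower numbers for stronger inhibition), compound 1 (`Cc1cc(C)c(CN2CCc3c(Cl)cc(-c4cn[nH]c4)c(Cl)c3C2=O)c(=O)[nH]1`) gives 1580 nM and compound 2 (`Cc1cc(C)c(CN2CCc3c(Cl)cc(-c4c(C)noc4C)c(Cl)c3C2=O)c(=O)[nH]1`) gives 25 nM as the lower of the two numbers. Compound 3 (`Cc1cc(C)c(CN2CCc3c(Cl)cc(-c4cn[nH]c4C)c(Cl)c3C2=O)c(=O)[nH]1`) has not yet been measured. It differs from compound 2 in one place, an aromatic carbon of the shared core (5-methyl-1H-pyrazol-4-yl in place of 3,5-dimethyl-1,2-oxazol-4-yl on an aromatic carbon) where 5-methyl-1H-pyrazol-4-yl stands in place of 3,5-dimethyl-1,2-oxazol-4-yl. For the measured compounds named here, the only measured step at that place is large and beyond the scatter (a 63-fold lower number from compound 1 to compound 2 (1.80 log units; beyond the scatter)) and runs from 1H-pyrazol-4-yl to 3,5-dimethyl-1,2-oxazol-4-yl. The entering group keeps the pyrazolyl type of compound 1 (1580 nM) but adds a methyl, so a partial return towards that higher number is expected. The expected change is smaller than the measured step (a 6.0-fold higher number from compound 2 to compound 3 (0.78 log units; beyond the scatter)) and points to weaker inhibition. In this assay compound 3 is estimated at 150 nM (40 nM to 600 nM).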

Compound 3, half-maximal inhibitory concentration in the KARPAS-422 assay: 1340 nM
Beside the measured number, compound 3's estimate is 8.9-fold (0.95 log units) below it; measured number above the stated range.
By their numbers in the KARPAS-422 assay, from the lowest: compound 2; then compounds 3 and 1 (each within the scatter of the next).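

In the KARPAS-422 assay, adding a single methyl to the pyrazolyl group does not recover the activity of compound 2, which gives 25 nM: methyl in place of hydrogen on an aromatic carbon gives a 1.2-fold lower number from compound 1 to compound 3 (0.07 log units; within the scatter). At this position, the large gain therefore does not follow from that one methyl, and replacing 3,5-dimethyl-1,2-oxazol-4-yl with 5-methyl-1H-pyrazol-4-yl gives a 54-fold higher number from compound 2 to compound 3 (1.73 log units; beyond the scatter). In a physicochemical assay for lipophilicity, at pH 7.4 (a higher number here means a more lipophilic compound, a lower number a more polar compound), compound 2 gives 3.1 and compound 3 gives 3.1. In the physicochemical assay, the same replacement gives no change at the digits printed from compound 2 to compound 3 (within the scatter), so the large step in the cell assay comes without a measured difference in distribution coefficient.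

No available evidence explains the step. The compounds shown also leave open whether the ring itself or the second methyl carries the difference, a question that a 3,5-dimethyl-1H-pyrazol-4-yl group on this carbon could help to separate.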